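Trimming benzyl to methyl on compound 2

A few compounds are considered here, and "the series" means these few. Any claim that something is new, unique, unknown or untested is made for them only; others in the source may bear on it.

Compound 1 `CS/C(=N\C(=O)c1ccno1)NC(=O)c1ccno1`: in a functional assay on HT-29 cells (Homo sapiens) for cytotoxicity, read by MTT assay, with a stated time of 72 h (on this read-out higher numbers stand for lower toxicity in this test and lower numbers for higher toxicity in this test), compound 1 gives > 100000 nM, a limit of the assay.
Compound 2 `O=C(/N=C(/NC(=O)c1ccno1)[Se]Cc1ccccc1)c1ccno1`: in this assay compound 2 gives > 100000 nM, likewise a limit.

Going by the values given here, compound 2 therefore stands where every value so far stands, namely at the limit of > 100000 nM in this assay, at which 2 of the 2 values shown sit. Among the compounds with values here, the one step between measured compounds, a step that the two limits leave unreadable from compound 1 to compound 2, cannot be sized, so it gives no direction for what follows. Compound 3 `C[Se]/C(=N\C(=O)c1ccno1)NC(=O)c1ccno1` differs from compound 2 by hydrogen in place of phenyl on a saturated chain carbon bound to a selenium atom. With no readable step to lean on, no change beyond the scatter can be expected in either direction. Compound 3 is therefore estimated at 150000 nM, within 30000 nM to 600000 nM, which means an expected step that the limit leaves unreadable from compound 2 to compound 3; it is expected that the measurement again reports only a limit.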

Compound 3, concentration lethal to 50% of the cells: > 100000 nM
Compound 3: no number, only a limit; the forecaster's own chance of this, stated with the estimate: 75%; the middle value does not contradict the limit.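

Going by these compounds alone, no step among compound 1, compound 2 and compound 3 can be read, since each value is only a limit of the assay: the limit of > 100000 nM in this assay, at which 3 of the 3 values shown sit. The compounds shown leave open whether benzyl to methyl, or selenium in place of sulfur, alters the read-out in this assay at all.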